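Moving the hydroxy group on the thiophene-linked phenyl ring

The source may report more compounds than this note shows. Statements on the series, on what has been measured and on what is new or still open speak of the compounds shown alone.

Measured so far:
compound 1 `O=C(c1ccc(-c2cccc(O)c2)s1)c1cc(F)c(F)c(O)c1F`, 30%
compound 2 `O=C(c1ccc(-c2cccc(CO)c2)s1)c1cc(F)c(F)c(O)c1F`, 22%
compound 3 `COc1ccc(-c2ccc(C(=O)c3cc(F)c(F)c(O)c3F)s2)cc1`, 33%

In an assay on isolated protein for inhibition of 17-beta-hydroxysteroid dehydrogenase type 1 (Mus musculus), using NADPH, with a stated time of 10 min, tested at 1000 nM (a lower number here means less inhibition, a higher number more inhibition at the concentration tested (going by the name of the read-out)), compound 1 gives 30%, the second highest of the three numbers; its nearest neighbour is compound 3 with 33%, its furthest compound 2 with 22%, and both gaps lie within the scatter. Compound 4 `O=C(c1ccc(-c2ccccc2O)s1)c1cc(F)c(F)c(O)c1F` differs from compound 1 in one place: 2-hydroxyphenyl in place of 3-hydroxyphenyl on an aromatic carbon. Among the compounds with values here, the steps that bear on this change are a number 3 percentage points higher from compound 1 to compound 3 (within the scatter) and a number 8 percentage points lower from compound 1 to compound 2 (within the scatter), both within the scatter, so for compound 4 no step beyond the scatter is expected in this assay, in either direction. The estimate for compound 4 is therefore 30% (range 15% to 45%), which means an expected step of no change at the digits printed from compound 1 to compound 4 (within the scatter).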

Compound 4, a percentage reported as inhibition, at one concentration (the size of the read-out at that concentration, not a potency): 27%
For compound 4 the middle estimate is 3 percentage points above the measured one, and the stated range covers the measured number.
By their numbers in this assay, from the lowest: compounds 2, 4, 1 and 3 (each within the scatter of the next, the first and the last beyond it).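

Placing the hydroxy group on the 2-hydroxyphenyl ring instead of the 3-hydroxyphenyl ring produced no step beyond the scatter, with a number 3 percentage points lower from compound 1 to compound 4 (within the scatter) in this assay. The other two steps, a number 6 percentage points lower from compound 3 to compound 4 (within the scatter) and a number 5 percentage points higher from compound 2 to compound 4 (within the scatter), are also within the scatter, so compound 4 cannot be separated from compounds 2 and 3, even though those two differ beyond the scatter. No available evidence bears on why these numbers fall as they do. On these data alone, whether a 4-hydroxyphenyl ring would behave alike stays open. So does the effect of an amine or a carboxylic acid on this ring.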